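A few compounds are considered here, and "the series" means these few. Any claim that something is new, unique, unknown or untested is made for them only; others in the source may bear on it.

Measured so far in a functional assay on A549 cells (Homo sapiens) for cytotoxicity, read by crystal violet staining, with a stated time of 3 days; on this read-out higher numbers stand for weaker inhibition and lower numbers for stronger inhibition:
compound 1, `COc1cc2c(cc1OC)C(/C(C)=N/NC(N)=S)N(S(=O)(=O)c1ccc([N+](=O)[O-])cc1)CC2`: compound 1 gives > 50 ug/mL, which is a limit of the assay and not a number.
compound 2, `COc1ccc(S(=O)(=O)N2CCc3cc(OC)c(OC)cc3C2/C(C)=N/NC(N)=S)cc1`: compound 2 gives > 50 ug/mL, again a limit rather than a number.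
compound 3, `C/C(=N\NC(N)=S)C1c2ccccc2CCN1S(=O)(=O)c1ccc([N+](=O)[O-])cc1`: compound 3 gives > 50 ug/mL, also a limit.

Compound 1 and compound 2 share a core and differ by methoxy in place of nitro on an aromatic carbon. The step that the two limits leave unreadable from compound 1 to compound 2 cannot be sized because the limit of > 50 ug/mL in this assay, at which 3 of the 3 values shown sit, holds both ends. Compound 3 carries a different core; the difference between the two cores is not broken down here. Compound 4, `COc1ccc(S(=O)(=O)N2CCc3ccccc3C2/C(C)=N/NC(N)=S)cc1`, is not yet measured and stands to compound 3 as compound 2 stands to compound 1: methoxy in place of nitro on an aromatic carbon, the same change at the same place.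

Every value shown ends at the limit, so the nitro-to-methoxy change gives no readable size anywhere in the series, and the change of core from compound 1 to compound 3 likewise ends at the limit. On that basis the step that the limit leaves unreadable from compound 3 to compound 4 is expected to stay flat. Compound 4 is estimated at 60 ug/mL, between 35 ug/mL and 100 ug/mL, most likely reported only as a limit.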

Compound 4, half-maximal inhibitory concentration: > 50 ug/mL
Compound 4 ended at the assay's limit; the forecaster's own chance of this, stated with the estimate: 85%; the middle value does not contradict the limit.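

In this assay compound 4 gives > 50 ug/mL, which is a limit and not a number. Compound 3 and compound 4 both end at a limit, so no new step can be read between them: the limit of > 50 ug/mL in this assay, at which 4 of the 4 values shown sit.

The compounds shown leave open whether methoxy in place of nitro, or the change of core, has any size in this assay.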